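A few compounds are considered here, and "the series" means these few. Any claim that something is new, unique, unknown or untested is made for them only; others in the source may bear on it.

Measured so far:
Compound 1 `N/C(=N\NC(=S)N1CCOCC1)c1ccccn1` — 18.3% in a functional assay on A-375 cells (Homo sapiens) for cytotoxicity, read by MTT assay, with a stated time of 72 h, tested at 10 uM; a higher number here means more inhibition of growth at the concentration tested, a lower number less inhibition of growth
Compound 2 `Cc1ccnc(/C(N)=N/NC(=S)N2CCOCC2)c1` — 86%
Compound 3 `Cc1ccnc(/C(N)=N/NC(=S)N2CCN(c3ccccn3)CC2)c1` — 76%

Compound 2 and compound 3 share one side of the molecule but carry different cores; how the two cores differ is not broken down here. Their values in this assay lie within the usual scatter of each other, so nothing can be said about which is more active. Compound 1 lies far below both.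

Compound 4 `N/C(=N\NC(=S)N1CCN(c2ccccn2)CC1)c1ccccn1` has not yet been measured. It is made from compound 3 by one change, (hydrogen in place of methyl on an aromatic carbon). Exactly the same change, (hydrogen in place of methyl on an aromatic carbon), has already been made from compound 2 to compound 1, and there it gave a number 67.7 percentage points lower from compound 2 to compound 1 (beyond the scatter).

The expectation for the new pair rests on that earlier step, because of a number 67.7 percentage points lower from compound 2 to compound 1 (beyond the scatter). The surroundings of the changed position are the same in both pairs, even though the cores differ, so a drop of similar size is expected from compound 3 to compound 4. The expected step is a number 61 percentage points lower from compound 3 to compound 4 (beyond the scatter). Compound 4 is therefore estimated at 15%, with a likely range from 5% to 45%.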

Compound 4, percent growth inhibition at one concentration: 74.4%
Estimate against measurement, compound 4: 59.4 percentage points below; the measured number lies above the stated range.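

In this assay, replacing 4-methylpyridin-2-yl with pyridin-2-yl gives a number 1.6 percentage points lower from compound 3 to compound 4 (within the scatter), so on this core the loss of the methyl group produces no readable change in growth inhibition. The large effect seen on the other core therefore does not carry over to this one: the same change on two cores in this assay, a number 67.7 percentage points lower (beyond the scatter) from compound 2 to compound 1 and a number 1.6 percentage points lower (within the scatter) from compound 3 to compound 4, 66.1 percentage points apart, beyond the scatter of two such steps. This shows that, for these two pairs, the result of the change depends on the core that carries it, but two pairs cannot show why, and they cannot show which step would be more typical on a third core.

On these data alone, it remains open how an ethyl group, a methoxy group or a chlorine atom at the same place on the ring would behave on each of the two cores. As far as these compounds go, it also remains open whether the sharp difference between the cores would persist at other concentrations or in other cell lines.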